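Changing the Amide Side Chain of Compound 3

This account rests on a few compounds, and the source may have more. Where it says the series, first, only, none or still open, it means among the compounds named here.

In an ADME assay on L02 cells (Homo sapiens) for cytotoxicity, read by MTT assay, with a stated time of 48 h (on this read-out lower numbers stand for stronger inhibition and higher numbers for weaker inhibition), compound 1 `CCOC(=O)CN(C)C(=O)c1ccc(C(CC)(CC)c2ccc(OCC(O)C(C)(C)C)c(C)c2)n1CC` gives 10100 nM, compound 2 `CCN(CC)CCCNC(=O)c1ccc(C(CC)(CC)c2ccc(OCC(O)C(C)(C)C)c(C)c2)n1CC` gives 2500 nM and compound 3 `CCn1c(C(=O)NCCN)ccc1C(CC)(CC)c1ccc(OCC(O)C(C)(C)C)c(C)c1` gives 2400 nM. Compound 3 therefore shares the low end of this small set with compound 2, as a 1.0-fold lower number from compound 2 to compound 3 (0.02 log units; within the scatter) shows. Compound 1 stands clearly apart, with a 4.2-fold lower number from compound 1 to compound 3 (0.62 log units; beyond the scatter) and also a 4.0-fold lower number from compound 1 to compound 2 (0.61 log units; beyond the scatter).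

Compound 4 `CCn1c(C(=O)N(C)CCC#N)ccc1C(CC)(CC)c1ccc(OCC(O)C(C)(C)C)c(C)c1` differs from compound 3 at one place: (2-cyanoethyl)(methyl)amino in place of (2-aminoethyl)amino on a carbonyl carbon. In short, (2-cyanoethyl)(methyl)amino sits in place of (2-aminoethyl)amino on a carbonyl carbon. The entering group resembles the ((ethoxycarbonyl)methyl)(methyl)amino group of compound 1 more closely than the chains of compound 2 or compound 3. Within the data shown here, the best guide is thus a 4.2-fold lower number from compound 1 to compound 3 (0.62 log units; beyond the scatter), read in reverse, although no measured compound carries a nitrile. A rise of similar size is expected, which makes the estimated change a 3.3-fold higher number from compound 3 to compound 4 (0.52 log units; beyond the scatter). The estimate for compound 4 is 8000 nM, with an expected range of 3500 nM to 18000 nM.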

Compound 4, half-maximal inhibitory concentration: 14900 nM
Compound 4: the middle estimate sits 1.9-fold (0.27 log units) below what was measured; low and high end bracket the measured number.
By their numbers in this assay, from the lowest: compounds 3 and 2 (each within the scatter of the next); then compounds 1 and 4 (each within the scatter of the next).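

In this assay, the number rises when (2-cyanoethyl)(methyl)amino replaces either amine-bearing chain on the carbonyl carbon: a 6.2-fold higher number from compound 3 to compound 4 (0.79 log units; beyond the scatter), and a 6.0-fold higher number from compound 2 to compound 4 (0.78 log units; beyond the scatter). The nitrile-bearing chain and the ester-bearing chain cannot be told apart, with a 1.5-fold higher number from compound 1 to compound 4 (0.17 log units; within the scatter), so all four compounds fall into two groups: the two with an amine on the chain and an amide hydrogen give low numbers, while the two with a methyl on the amide nitrogen and no chain amine give high numbers. Nothing measured here explains this split.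

The methyl and the amine change together in these compounds, so their contributions remain unseparated. A (2-aminoethyl)(methyl)amino group or a (2-cyanoethyl)amino group on the same carbonyl carbon would pull the two apart.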